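The source may hold more compounds than are shown below. What is called first, only, known or untested is meant among the compounds shown, and "the series" means these compounds.

Measured so far in an ADME assay on Huh-7 cells (Homo sapiens) for cytotoxicity, read by MTT assay, with a stated time of 4 h, at 37 degrees C; on this read-out higher numbers stand for lower toxicity in this test and lower numbers for higher toxicity in this test

- compound 1 `Cn1c(=O)c(-c2c(Br)cccc2Br)cc2c(N)nc(Nc3ccccc3)nc21` gives 800 nM
- compound 2 `COc1ccc(Nc2nc3[nH]c(=O)c(-c4ccc(F)cc4)cc3c(=O)[nH]2)cc1` gives 46000 nM
- compound 3 `Cn1c(=O)c(-c2c(Cl)cccc2Cl)cc2c(N)nc(N)nc21` gives 120000 nM

Compound 1 stands lowest of the three, with compound 2 and compound 3 both higher by more than the scatter. Compound 4 `Cn1c(=O)c(-c2ccccc2)cc2c(N)nc(Nc3ccccc3)nc21` differs from compound 1 by phenyl in place of 2,6-dibromophenyl on an aromatic carbon with phenyl in place of 2,6-dibromophenyl on an aromatic carbon. Going by the values given here, no measured pair differs in one place only, so nothing measured shows this change directly. Compound 2 at 46000 nM and compound 3 at 120000 nM differ from compound 1 in more than one place and offer only a loose guide. In this assay a moderate upward step is expected, beyond the scatter but smaller than those gaps. The estimated step is a 3.8-fold higher number from compound 1 to compound 4 (0.57 log units; beyond the scatter) and it remains uncertain. For compound 4 the estimated value is 3000 nM with an expected range from 600 nM to 20000 nM in all.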

Compound 4, half-maximal cytotoxic concentration: 23500 nM
Estimate against measurement, compound 4: 7.8-fold (0.89 log units) below, and the stated range ends below it.
By their numbers in this assay, from the lowest: compound 1; then compounds 4 and 2 (each within the scatter of the next); then compound 3.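

In this assay, going by these compounds alone, phenyl in place of 2,6-dibromophenyl on this aromatic carbon gives a 29-fold higher number from compound 1 to compound 4 (1.47 log units; beyond the scatter), a large step and the first direct reading of any change at this position. On the core of compound 1, the low number therefore goes with the two bromine atoms of this group, and losing them moves the number well beyond the scatter. Nothing given here explains the step.

From the compounds shown here alone, it remains open whether a phenyl carrying a single bromine would keep the low number of compound 1. The same holds for 2,6-dimethylphenyl, which carries methyl groups in place of the bromine atoms.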